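This account rests on a few compounds, and the source may have more. Where it says the series, first, only, none or still open, it means among the compounds named here.

In an ADME assay on S9 fraction from liver (Rattus norvegicus) for metabolic stability, with a stated time of 1 h (a higher number here means that more of the compound is left, a lower number that less of the compound is left), three compounds built on the same core have been measured. Compound 1 `N#Cc1cnc(NCc2cnccc2C(F)(F)F)cc1NC[C@H]1C[C@H](O)C1` gives 61%, compound 2 `N#Cc1cnc(NCc2cnccc2C(F)(F)F)cc1N[C@H]1CC[C@@H](O)CC1` gives 6% and compound 3 `CO[C@H]1CC[C@@H](Nc2cc(NCc3cnccc3C(F)(F)F)ncc2C#N)CC1` gives 1%. Compound 3 therefore sits with compound 2 at the bottom of this small set, within the scatter of it and far under compound 1.

Compound 4 `N#Cc1cnc(NCc2cnccc2C(F)(F)F)cc1NC[C@H]1CC[C@H](O)CC1` keeps the core and rearranges the side group: (4-hydroxycyclohexyl)methyl in place of 4-methoxycyclohexyl on a nitrogen on an aromatic ring. Among the compounds with values here, three measured steps bear on this change. Exchanging the hydroxy hydrogen for methyl gave a number 5 percentage points lower from compound 2 to compound 3 (within the scatter), which lies within the scatter. The two large steps are a number 55 percentage points lower from compound 1 to compound 2 (beyond the scatter) and a number 60 percentage points lower from compound 1 to compound 3 (beyond the scatter). Within the data shown here, both start from the only measured compound with a ring attached through methyl. Compound 4 shares that kind of attachment with compound 1, but it has the six-membered ring of compound 2. The data cannot separate ring size from attachment, so only part of the large gap is likely to be recovered.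

The expected change is a clear rise, a number 29 percentage points higher from compound 3 to compound 4 (beyond the scatter), though smaller than those large steps. For compound 4 the estimated value is 30%, with an expected range of 8% to 60%.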

Compound 4, percent of the compound remaining: 6%
Estimate against measurement, compound 4: 24 percentage points above, outside the stated range (below it).
By their numbers in this assay, from the lowest: compounds 3, 2 and 4 (each within the scatter of the next); then compound 1.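

In this assay, putting a methyl link between the nitrogen and the six-membered ring gives no change at the digits printed from compound 2 to compound 4 (within the scatter) and so does not restore the higher number of compound 1; the step from the methoxy compound is likewise small, a number 5 percentage points higher from compound 3 to compound 4 (within the scatter) in this same read-out. With the attachment through methyl now held constant, 4-hydroxycyclohexyl in place of 3-hydroxycyclobutyl gives a number 55 percentage points lower from compound 1 to compound 4 (beyond the scatter), so among these four compounds the large gap follows the ring and not the methyl attachment. Nothing available explains why the two rings differ so strongly.

From the compounds shown here alone, whether a (3-hydroxycyclopentyl)methyl group would stay near compound 1 or fall towards compound 4 remains open. So does whether the cyclobutyl ring keeps its number with an amine in place of the hydroxy group.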